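A few compounds are considered here, and "the series" means these few. Any claim that something is new, unique, unknown or untested is made for them only; others in the source may bear on it.

Of the compounds shown here, three have been tested in a functional assay on PC-3 cells (Homo sapiens) for inhibition, read by MTT assay, with a stated time of 48 h; a higher number here means a weaker inhibitor, a lower number a stronger inhibitor.

Compound 1 `COc1ccc(CN(c2cc(OC)c(OC)c(OC)c2)S(=O)(=O)c2ccc(C(C)(C)C)cc2)cc1` gives 28600 nM.
Compound 2 `COc1cc(N(Cc2ccc(F)cc2)S(=O)(=O)c2ccc(C)cc2)cc(OC)c1OC` gives 20700 nM.
Compound 3 `Cc1ccc(S(=O)(=O)N(Cc2nc3ccccc3[nH]2)c2ccc(F)cc2)cc1` gives 45000 nM.

Compound 3 has the highest of the three numbers, which means the weakest inhibition of the three. Its nearest neighbour is compound 1, whose number sits within the usual scatter of compound 3, so the two cannot be told apart. Compound 2 lies further off, beyond the scatter, so compound 2 inhibits more strongly than compound 3.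

Compound 4 `Cc1ccc(S(=O)(=O)N(Cc2nc3ccccc3[nH]2)c2ccccc2)cc1` is not yet measured. It differs from compound 3 only by hydrogen in place of fluoro on an aromatic carbon. Among the compounds with values here, with no pair of measured compounds showing this change, the expectation for this assay is a step of a 1.1-fold higher number from compound 3 to compound 4 (0.05 log units; within the scatter), not beyond the scatter. Compound 4 is therefore estimated at 50000 nM, between 20000 nM and 120000 nM.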

Compound 4, half-maximal inhibitory concentration: > 50000 nM
Compound 4: no number, only a limit; the forecaster's own chance of this, stated with the estimate: 25%; the middle value lies on the limit itself.
By their numbers in this assay, from the lowest: compounds 2, 1 and 3 (each within the scatter of the next, the first and the last beyond it). At a limit, above all of these: compound 4.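

Compound 4 gives > 50000 nM in this assay, which is a limit and not a number. Within the data shown here, putting phenyl in place of 4-fluorophenyl gives an at least 1.1-fold higher number from compound 3 to compound 4 (0.04 log units; that floor lies within the scatter), the first reading of any change at this position, and it is only a floor, so the fluoro may matter little or a great deal. The true size of the step cannot be read past that limit: the limit of > 50000 nM in this assay, at which 1 of the 4 values shown sits.

From the compounds shown here alone, whether an amine or a carboxylic acid on this aromatic carbon would give a lower number stays open. Among these compounds, compound 3 and compound 4 form the only pair differing in one place, so it is also open whether this change behaves alike on another core.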